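Moving from 4-fluorobenzyl to 4-methylphenyl on sulfur

This account rests on a few compounds, and the source may have more. Where it says the series, first, only, none or still open, it means among the compounds named here.

Measured in a functional assay on DU-145 cells (Homo sapiens) for inhibition, read by trypan blue exclusion, with a stated time of 96 h; a higher number here means a weaker inhibitor of growth, a lower number a stronger inhibitor of growth:
- compound 1 `COc1cc(OC)c(/C=C(\C(=O)c2ccc(Br)cc2)S(=O)(=O)Cc2ccc(Cl)cc2)c(OC)c1`: 25000 nM
- compound 2 `COc1cc(OC)c(/C=C(/SCc2ccc(F)cc2)C(=O)c2ccc(Br)cc2)c(OC)c1`: 1000 nM

Of the two numbers in this assay, compound 2 has the lower, at 1000 nM. Compound 3 `COc1cc(OC)c(/C=C(/Sc2ccc(C)cc2)C(=O)c2ccc(Br)cc2)c(OC)c1` has not yet been measured. It carries 4-methylphenyl in place of 4-fluorobenzyl on a sulfur.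

Going by the values given here, only one measured step bears on this, and only loosely. It is a 25-fold lower number from compound 1 to compound 2 (1.40 log units; beyond the scatter), a large change, made with (4-fluorobenzyl)sulfanyl in place of (4-chlorobenzyl)sulfonyl. That step replaced the sulfonyl, whereas compound 3 keeps the sulfanyl sulfur of compound 2, so its size does not carry over. Among the compounds with values here, no measured pair tests the present swap, so only a small rise is expected, not one beyond the scatter. The expected step is a 1.5-fold higher number from compound 2 to compound 3 (0.18 log units; within the scatter). For compound 3 the estimate is 1500 nM, with an expected range from 400 nM to 6000 nM.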

Compound 3, concentration for 50% growth inhibition: > 100000 nM
Compound 3 ended at the assay's limit; the forecaster's own chance of this, stated with the estimate: 5%; middle value at least 66-fold (1.82 log units) away from the limit.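

In this assay compound 3 gives only a limit of the assay, not a number: the limit of > 100000 nM in this assay, at which 1 of the 3 values shown sits.

The group on this sulfur matters a great deal: 4-methylphenyl in place of 4-fluorobenzyl gives an at least 100-fold higher number from compound 2 to compound 3 (2.00 log units; beyond the scatter). A sulfanyl sulfur alone is therefore not enough to keep growth inhibition, since (4-methylphenyl)sulfanyl in place of (4-chlorobenzyl)sulfonyl gives an at least 4.0-fold higher number from compound 1 to compound 3 (0.60 log units; beyond the scatter), the reverse direction of the earlier step to the (4-fluorobenzyl)sulfanyl group.

This swap alters the link to the ring and the ring substituent together, so the compounds shown cannot separate the two, and 4-fluorophenyl or 4-methylbenzyl on the sulfur would be needed to do so. They also leave open how a longer chain, such as 2-phenylethyl, would behave at this sulfur.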